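The compounds below may be only part of what the source reports. "The series", "measured", "known", "first", "only" and "open" are said of these compounds alone.

Measured so far:
compound 1 `CCCCCn1ccc2cc(/C(C)=C/C(=O)Nc3ccccc3OCCCC(=O)O)ccc21` — 23 nM
compound 2 `C/C(=C\C(=O)Nc1ccccc1OCCCC(=O)O)c1ccc2c(ccn2Cc2ccc(C)cc2)c1` — 88 nM
compound 3 `CCCCc1ccc(Cn2ccc3cc(/C(C)=C/C(=O)Nc4ccccc4OCCCC(=O)O)ccc32)cc1` — 100 nM

In an assay on Prostate gland for inhibition of steroid 5-alpha-reductase (Rattus norvegicus) (a higher number here means a weaker inhibitor, a lower number a stronger inhibitor), compound 3 gives the highest of the three numbers. Its gap to compound 2 is small, a 1.1-fold higher number from compound 2 to compound 3 (0.06 log units; within the scatter), and lies within the scatter, so the two cannot be ordered; its gap to compound 1 is larger, a 4.3-fold higher number from compound 1 to compound 3 (0.64 log units; beyond the scatter), and lies beyond the scatter.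

Compound 4 `CCCCCC(c1ccccc1)n1ccc2cc(/C(C)=C/C(=O)Nc3ccccc3OCCCC(=O)O)ccc21` differs from compound 3 in one place: 1-phenylhexyl in place of 4-butylbenzyl on an aromatic nitrogen. Going by the values given here, no measured step is of the same kind, but two steps bear on it. Both show what happens when an aryl group takes the place of butyl on the saturated chain carbon bound to the aromatic nitrogen: a 3.8-fold higher number from compound 1 to compound 2 (0.58 log units; beyond the scatter) and a 4.3-fold higher number from compound 1 to compound 3 (0.64 log units; beyond the scatter). Compound 4 carries on that carbon both a phenyl and a pentyl chain, so it combines a feature of compound 1 with a feature of compounds 2 and 3. A number between those of compound 1 and compound 3 is therefore expected in this assay, with a wide range. The estimate for compound 4 in this assay is 50 nM, between 18 nM and 150 nM, which means an expected step of a 2.0-fold lower number from compound 3 to compound 4 (0.30 log units; within the scatter).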

Compound 4, half-maximal inhibitory concentration: 25 nM
The estimate for compound 4 lay 2.0-fold (0.30 log units) above the measured number; the measured number falls inside the stated range.
By their numbers in this assay, from the lowest: compounds 1 and 4 (each within the scatter of the next); then compounds 2 and 3 (each within the scatter of the next).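

In this assay, 1-phenylhexyl in place of 4-butylbenzyl on the aromatic nitrogen gives a 4.0-fold lower number from compound 3 to compound 4 (0.60 log units; beyond the scatter) and 1-phenylhexyl in place of 4-methylbenzyl gives a 3.5-fold lower number from compound 2 to compound 4 (0.55 log units; beyond the scatter) while remaining an aryl-bearing group on the same saturated carbon position. Compound 2 and compound 3 had linked an aryl group at this place to a higher number than pentyl, but compound 4 shows that a phenyl ring on the carbon bound to the nitrogen does not by itself bring that higher number. Set against pentyl, the new group gives a 1.1-fold higher number from compound 1 to compound 4 (0.04 log units; within the scatter), so compound 1 and compound 4 cannot be ordered even though only the group in compound 4 carries a six-membered aromatic ring. Nothing available here explains these steps.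

The compounds shown leave open how much of this result belongs to the pentyl part of 1-phenylhexyl and how much to its phenyl ring, a question that an unsubstituted benzyl group or a 1-phenylethyl group would help to settle. Also open, on these data alone, is whether a hydroxyl group or an amine on that phenyl ring would leave the number of compound 4 unchanged.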